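A New Halogenated Group at the Assay Limit

The source may hold more compounds than are shown below. What is called first, only, known or untested is meant among the compounds shown, and "the series" means these compounds.

Compound 3 (`COc1cccc(CNc2ncnc3c2ncn3[C@@H]2O[C@H](CO)[C@@H](O)[C@H]2O)c1OC`) gives > 166000 nM in a functional assay on MCF cells (Homo sapiens) for antiproliferative activity, with a stated time of 72 h (on this read-out higher numbers stand for weaker inhibition and lower numbers for stronger inhibition), as a limit, not a number. Compound 4 (`OC[C@H]1O[C@@H](n2cnc3c(NCc4ccc(F)cc4Cl)ncnc32)[C@H](O)[C@@H]1O`) carries 2-chloro-4-fluorophenyl in place of 2,3-dimethoxyphenyl (2-chloro-4-fluorophenyl in place of 2,3-dimethoxyphenyl on a saturated chain carbon bound to a nitrogen on an aromatic ring). Compound 1 (`OC[C@H]1O[C@@H](n2cnc3c(NCc4ccccc4F)ncnc32)[C@H](O)[C@@H]1O`) also shows only a limit (> 166000 nM). Compound 2 (`OC[C@H]1O[C@@H](n2cnc3c(NCc4cccc(F)c4)ncnc32)[C@H](O)[C@@H]1O`) gives a true number (15300 nM). Two readable steps bear on the change: 3-fluorophenyl for 2-fluorophenyl gave an at least 10-fold lower number from compound 1 to compound 2 (1.03 log units; beyond the scatter) and 2,3-dimethoxyphenyl for 3-fluorophenyl gave an at least 10-fold higher number from compound 2 to compound 3 (1.03 log units; beyond the scatter) in this assay. Both are large. Like both groups that stop at the limit, 2-chloro-4-fluorophenyl has a group at its 2 position, unlike 3-fluorophenyl. Only a modest gain is therefore expected: an at least 1.8-fold lower number from compound 3 to compound 4 (0.26 log units; that floor lies within the scatter) is estimated, toward a lower number if readable at all. Compound 4 is estimated at 90000 nM with a range of 20000 nM to 200000 nM and may again read as a limit.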

Compound 4, half-maximal inhibitory concentration: > 166000 nM
Compound 4: only a limit was reported (the forecaster's own chance of this, stated with the estimate: 60%); middle value at least 1.8-fold (0.26 log units) away from the limit.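

In this assay, 2-chloro-4-fluorophenyl proves to be a third group that gives no true number, and the steps to compound 4 from compound 1 and compound 3 cannot be read, as both ends of each are limits. Against 3-fluorophenyl, the change gives an at least 10-fold higher number from compound 2 to compound 4 (1.03 log units; beyond the scatter). Compounds 1, 3 and 4 cannot be ranked against one another because they share one limit: the limit of > 166000 nM in this assay, at which 3 of the 4 values shown sit.

Still open, going by these compounds, is whether 4-fluorophenyl alone would give a true number. It is also unknown whether 3-chlorophenyl would match compound 2.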